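A Thiophene Sulfonamide After Two Analogues at the Limit

The source may hold more compounds than are shown below. What is called first, only, known or untested is meant among the compounds shown, and "the series" means these compounds.

In an assay on cells for inhibition of HSP60/HSP10 (Homo sapiens), with a stated time of 60 min (on this read-out lower numbers stand for stronger inhibition and higher numbers for weaker inhibition), compound 1 `COc1cccc(S(=O)(=O)Nc2ccc3oc(-c4ccccc4)nc3c2)c1` reaches only the assay limit, > 100000 nM.
In this assay compound 2 `O=S(=O)(Nc1ccc2oc(-c3ccccc3)nc2c1)c1ccccc1F` likewise reaches only the assay limit, > 100000 nM.

Going by the values given here, the one measured step, a step that the two limits leave unreadable from compound 1 to compound 2, cannot be sized because both values sit at the limit of > 100000 nM in this assay, at which 2 of the 2 values shown sit. Compound 2 therefore stands at the limit, with no number of its own. Compound 3 `O=S(=O)(Nc1ccc2oc(-c3ccccc3)nc2c1)c1cccs1` differs from compound 2 by thiophen-2-yl in place of 2-fluorophenyl on a sulfonyl sulfur. No readable step bears on this change, so no move beyond the scatter is expected. The expected step of a number no higher from compound 2 to compound 3 (the limit leaves the size open) is estimated as none beyond the scatter. Compound 3 is estimated at 100000 nM, within 30000 nM to 300000 nM.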

Compound 3, half-maximal inhibitory concentration: 90000 nM
Beside the measured number, compound 3's estimate is 1.1-fold (0.05 log units) above it; the range from low to high includes it.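

In this assay, thiophen-2-yl on the sulfonyl sulfur gives the first number of its own rather than a limit, which shows that a change at this place can bring a reading inside the range of the assay: the limit of > 100000 nM in this assay, at which 2 of the 3 values shown sit.

The change gives an at least 1.1-fold lower number from compound 2 to compound 3 (0.04 log units; that floor lies within the scatter) and an at least 1.1-fold lower number from compound 1 to compound 3 (0.04 log units; that floor lies within the scatter). Going by these compounds, each of these is only a floor, so the true size of both steps stays open.

The compounds shown leave open how a furan-2-yl ring or a longer chain would read on the same sulfonyl sulfur. They also leave open whether an amine or a carboxylic acid on the thiophene would lower the number further.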